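A Second Chloro Group and Expected Solubility

A few compounds are considered here, and "the series" means these few. Any claim that something is new, unique, unknown or untested is made for them only; others in the source may bear on it.

Compound 1 `Cc1cc(NC(=O)Nc2ccc(C)c(Cl)c2)c2ccccc2n1`: 300 nM
Compound 2 `COc1ccc(NC(=O)Nc2cc(C)nc3ccccc23)cc1`: 19800 nM
Compound 3 `Cc1cc(NC(=O)Nc2ccc(Cl)cc2)c2ccccc2n1`: 1400 nM

In a physicochemical assay for solubility, at pH 7.4 (on this read-out higher numbers stand for higher solubility and lower numbers for lower solubility), compound 3 stands second highest of the three numbers, above compound 1 and well below compound 2. Compound 4 `Cc1cc(NC(=O)Nc2ccc(Cl)c(Cl)c2)c2ccccc2n1` differs from compound 3 by chloro in place of hydrogen on an aromatic carbon. Among the compounds with values here, the only measured step, a 14-fold lower number from compound 2 to compound 3 (1.15 log units; beyond the scatter), shows that a chloro group on this ring went with a much lower number. Compound 1, which carries a chloro group together with a methyl group on that ring, gives 300 nM, lower again than compound 3. A second chloro group is therefore expected to lower the number further, with a 4.0-fold lower number from compound 3 to compound 4 (0.60 log units; beyond the scatter). Compound 4 is estimated at 350 nM, between 100 nM and 1200 nM.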

Compound 4, solubility: 300 nM
Estimate against measurement, compound 4: 1.2-fold (0.07 log units) above; low and high end bracket the measured number.
By their numbers in this assay, from the lowest: compounds 1 and 4 (each within the scatter of the next); then compound 3; then compound 2.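

In this assay, within the data shown here, a chloro group placed ortho to the chloro group already on the ring gave a 4.7-fold lower number from compound 3 to compound 4 (0.67 log units; beyond the scatter), the first direct reading of a change at this position. Chloro in place of methyl gave no change at the digits printed from compound 1 to compound 4 (within the scatter), so these two groups are not told apart on this ring when the added chloro group is present. No measurement here bears on why either step occurs.

Still open, on these data alone, is how an amine or a carboxylic acid at this position would read in this assay. As far as these compounds go, whether a second chloro group would give a similar step on another core also stays open.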